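This account rests on a few compounds, and the source may have more. Where it says the series, first, only, none or still open, it means among the compounds named here.

Compound 1, `CC(C)c1ccc(-c2nc(SCc3cn(CC(=O)NC(=O)Nc4ccccn4)nn3)nc(Nc3cccc(C(F)(F)F)c3)c2C#N)cc1`: 24200 nM in a functional assay on ECa-109 cells (Homo sapiens) for inhibition, read by MTT assay, with a stated time of 72 h; a lower number here means a stronger inhibitor, a higher number a weaker inhibitor.
Compound 2, `COc1ccccc1Nc1nc(SCc2cn(CC(=O)NC(=O)Nc3ccccn3)nn2)nc(-c2ccc(C(C)C)cc2)c1C#N`: 8960 nM in this assay.

Among these two numbers compound 2 stands lowest, and the one change between them, from compound 1 to compound 2 at the nitrogen on an aromatic ring, gave a 2.7-fold lower number from compound 1 to compound 2 (0.43 log units; beyond the scatter). Compound 3, `COc1ccccc1Nc1nc(SCc2cn(CC(=O)NC(=O)Nc3ccccn3)nn2)nc(-c2ccc(C)cc2)c1C#N`, has not been measured in this assay. It keeps everything of compound 2 except one group: methyl in place of isopropyl on an aromatic carbon. For the measured compounds named here, the only measured step concerns a different part of the shared core, so no measured step bears on this change, and there is nothing here to say which way it should move the number. Compound 3 is therefore expected to land close to compound 2, with an estimated step of a 1.1-fold higher number from compound 2 to compound 3 (0.03 log units; within the scatter). The estimated value for compound 3 in this assay is 9500 nM, within a range of 3000 nM to 30000 nM.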

Compound 3, half-maximal inhibitory concentration: 7850 nM
For compound 3 the middle estimate is 1.2-fold (0.08 log units) above the measured one, and the stated range covers the measured number.
By their numbers in this assay, from the lowest: compounds 3 and 2 (each within the scatter of the next); then compound 1.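

Going from 4-isopropylphenyl to 4-methylphenyl gave a 1.1-fold lower number from compound 2 to compound 3 (0.06 log units; within the scatter) in this assay, and this is the first reading at this position of the shared core. Swapping isopropyl, with 3 heavy atoms, for methyl, with 1, therefore leaves the number where repeat measurements could place it anyway. At this level of activity, the size of this carbon group on the aromatic ring makes no difference that can be told apart from scatter. No measurement in hand gives a reason for this result.

Only these two carbon groups have been seen here, so a plain hydrogen, a longer chain, an amine or a carboxylic acid in the same place could read quite differently. Going by these compounds, it also remains open whether methyl and isopropyl would still match with 3-(trifluoromethyl)phenyl on the nitrogen, as in compound 1.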